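The compounds below may be only part of what the source reports. "The series", "measured", "known", "first", "only" and "open" are said of these compounds alone.

Working notes on the selenium-bearing series.

Compound 1 `C[Se]c1nc([Se]C)c2cccnc2n1` gives "not determined" (no result reported) in a functional assay on CCRF-CEM cells (Homo sapiens) for cytotoxicity, read by MTT assay, with a stated time of 72 h; on this read-out higher numbers stand for weaker inhibition of growth and lower numbers for stronger inhibition of growth. Compound 2 `Nc1nc([SeH])nc2ncccc12` gives 61500 nM in this assay. Compound 3 `CCCCC[Se]c1nc(N)c2cccnc2n1` gives 42800 nM in this assay, the lower of the two numbers reported, though the change from compound 2 to compound 3 a 1.4-fold lower number from compound 2 to compound 3 (0.16 log units; within the scatter) places it within the scatter of compound 2. The next member, compound 4 `C[Se]c1nc(N)c2cccnc2n1`, differs from compound 3 by hydrogen in place of butyl on a saturated chain carbon bound to a selenium atom. Going by the values given here, only the step from compound 2 to compound 3 a 1.4-fold lower number from compound 2 to compound 3 (0.16 log units; within the scatter) bears on a change at this position, and it was within the scatter, so no step beyond the scatter is expected in this assay. Compound 4 is therefore estimated at 50000 nM, between 20000 nM and 125000 nM, a step of a 1.2-fold higher number from compound 3 to compound 4 (0.07 log units; within the scatter) that is expected to stay inside the scatter.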

Compound 4, concentration for total growth inhibition: > 100000 nM
Compound 4 gave a limit, no number; the forecaster's own chance of this, stated with the estimate: 10%; middle value at least 2.0-fold (0.30 log units) from the limit.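

Cutting the group on selenium from pentyl to methyl gives an at least 2.3-fold higher number from compound 3 to compound 4 (0.36 log units; beyond the scatter), the first step at this position to pass the scatter in this assay. The comparison with hydrogen on selenium is less firm, at an at least 1.6-fold higher number from compound 2 to compound 4 (0.21 log units; that floor lies within the scatter), so it gives no order for those two compounds. Compound 4 stands at a limit, not a number: the limit of > 100000 nM in this assay, at which 1 of the 4 values shown sits.

On these data alone, how far compound 4 lies past that limit stays open, and so does the true size of both steps. Also open, as far as these compounds go, is how a propyl chain, a longer chain such as octyl, or a chain ending in a carboxylic acid would read at this position.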